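Quinolin-8-yl to isoquinolin-1-yl at the aryl ether

The source may report more compounds than this note shows. Statements on the series, on what has been measured and on what is new or still open speak of the compounds shown alone.

Compound 1: `COC(=O)c1cc(OCC(=O)[C@H](CC(=O)O)NC(=O)[C@@H](NC(=O)COc2cccc3ccccc23)C(C)C)no1`; in a functional assay on Jurkat cells (Homo sapiens) for inhibition (on this read-out higher numbers stand for weaker inhibition and lower numbers for stronger inhibition), compound 1 gives 71000 nM.
Compound 2: `CC(C)[C@H](NC(=O)COc1cccc2ccccc12)C(=O)N[C@@H](CC(=O)O)C(=O)CSc1nncn1C`; in this assay compound 2 gives > 200000 nM, a limit of the assay rather than a number.
Compound 3: `CC(C)[C@H](NC(=O)COc1cccc2ccccc12)C(=O)N[C@@H](CC(=O)O)C(=O)COc1cccc2cccnc12`; in this assay compound 3 gives > 200000 nM, again a limit and not a number.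

Compound 3 therefore stands at the weak end of what was measured; its value is the limit at which two of the three values sit, as stated in the limit of > 200000 nM in this assay, at which 2 of the 3 values shown sit. Compound 4, `CC(C)[C@H](NC(=O)COc1cccc2ccccc12)C(=O)N[C@@H](CC(=O)O)C(=O)COc1nccc2ccccc12`, differs from compound 3 by isoquinolin-1-yl in place of quinolin-8-yl on an oxygen on a saturated carbon.

Two measured steps give some bearing. The change from compound 1 to the quinolinyl ether of compound 3 was an at least 2.8-fold higher number from compound 1 to compound 3 (0.44 log units; beyond the scatter), and the change to the triazolyl thioether was an at least 2.8-fold higher number from compound 1 to compound 2 (0.44 log units; beyond the scatter). The step between them, a step that the two limits leave unreadable from compound 2 to compound 3, cannot be read. For the measured compounds named here, no measured step exchanges one bicyclic aryl ether for another, so no change beyond the scatter is expected in this assay from compound 3 to compound 4.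

Compound 4 is therefore estimated at 250000 nM, within 80000 nM to 800000 nM. The expected step is a step that the limit leaves unreadable from compound 3 to compound 4, with a real chance that only a limit is reported again.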

Compound 4, half-maximal inhibitory concentration: 106000 nM
The estimate for compound 4 lay 2.4-fold (0.37 log units) above the measured number; the measured number falls inside the stated range.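

Replacing quinolin-8-yl with isoquinolin-1-yl, two groups with the same atoms joined differently, gives a measured number rather than a limit in this assay for a bicyclic aryl ether at this position: an at least 1.8-fold lower number from compound 3 to compound 4 (0.27 log units; that floor lies within the scatter). Against the triazolyl thioether the picture is the same, with an at least 1.8-fold lower number from compound 2 to compound 4 (0.27 log units; that floor lies within the scatter), and since both of these floors lie within the scatter, neither one alone establishes a real change. The earlier compounds shown here showed only that replacing the 5-(methoxycarbonyl)-1,2-oxazol-3-yl group could take the value to a limit, as in compound 2 and compound 3, whereas this result shows that such a replacement need not do so, with a 1.5-fold higher number from compound 1 to compound 4 (0.17 log units; within the scatter), a step that leaves compound 1 and compound 4 indistinguishable.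

Going by these compounds, compound 3 is known only as a limit, so the true size of the step from quinolin-8-yl to isoquinolin-1-yl stays open: the limit of > 200000 nM in this assay, at which 2 of the 4 values shown sit. Also open, on these data alone, is whether an amine or a chlorine on the isoquinolin-1-yl group would give a number clearly beyond the scatter from that of compound 4.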